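A few compounds are considered here, and "the series" means these few. Any claim that something is new, unique, unknown or untested is made for them only; others in the source may bear on it.

Series so far in an in vivo ADME assay on the whole organism (Cavia porcellus); a lower number here means that the compound disappears faster, a higher number that the compound lasts longer:
compound 1 `CCCC(NC(=O)c1ccc(C(=N)N)cc1)C(C)(C)C(=O)N1CCC(CC(=O)O)CC1` at 0.9 h
compound 2 `CC(C)C(NC(=O)c1ccc(C(=N)N)cc1)C(C)(C)C(=O)N1CCC(CC(=O)O)CC1` at 0.8 h
compound 3 `C/C=C/C(NC(=O)c1ccc(C(=N)N)cc1)C(C)(C)C(=O)N1CCC(CC(=O)O)CC1` at 0.933 h

Compound 3 is not separated from the other two, with a 1.0-fold higher number from compound 1 to compound 3 (0.02 log units; within the scatter) and a 1.2-fold higher number from compound 2 to compound 3 (0.07 log units; within the scatter) as the steps that reach it. The next change leads to compound 4 `CCCCC(NC(=O)c1ccc(C(=N)N)cc1)C(C)(C)C(=O)N1CCC(CC(=O)O)CC1` and is butyl in place of prop-1-en-1-yl on a saturated chain carbon bound to an amide-type nitrogen and a saturated chain carbon.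

All measured steps at this place bear on it. Besides the two above, there is a 1.1-fold lower number from compound 1 to compound 2 (0.05 log units; within the scatter) as the third, and none of the three leaves the scatter. Butyl itself has no measurement yet, so this rests on propyl, isopropyl and prop-1-en-1-yl alone. No step beyond the scatter is therefore expected in this assay. The estimated step is a 1.0-fold lower number from compound 3 to compound 4 (0.02 log units; within the scatter), which stays within the scatter. For compound 4 the expected half-life is 0.9 h, with an estimated range of 0.6 h to 1.3 h as its ends.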

Compound 4, half-life: 1.03 h
The estimate for compound 4 lay 1.1-fold (0.06 log units) below the measured number, within the range that was stated.
By their numbers in this assay, from the lowest: compounds 2, 1, 3 and 4 (each within the scatter of the next).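

Butyl does not separate from any earlier group at this place on a saturated chain carbon bound to an amide-type nitrogen and a saturated chain carbon in this assay: the steps are a 1.1-fold higher number from compound 3 to compound 4 (0.04 log units; within the scatter) and a 1.3-fold higher number from compound 2 to compound 4 (0.11 log units; within the scatter). Read as methyl in place of hydrogen on a saturated chain carbon, four bonds along the chain from an amide-type nitrogen, the extension of propyl gives a 1.1-fold higher number from compound 1 to compound 4 (0.06 log units; within the scatter). All four groups now lie within the scatter of one another, so neither extension to butyl, branching as isopropyl nor the double bond of prop-1-en-1-yl has moved the half-life in this set.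

Nothing available accounts for this flat result. From the compounds shown here alone, whether a chain longer than butyl, a cyclohexyl ring, an amine or a hydroxyl at this place would shift the half-life remains open.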